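This account rests on a few compounds, and the source may have more. Where it says the series, first, only, none or still open, it means among the compounds named here.

Measured so far in an assay on HEK293 cells for positive allosteric modulation of metabotropic glutamate receptor 3 (Rattus norvegicus), read by thallium flux, with a stated time of 2.5 min; on this read-out higher numbers stand for an effect only at larger amounts of compound and lower numbers for an effect already at smaller amounts:
compound 1 `Cc1c(OCCCCOCOc2ccc(C(=O)O)cc2)ccc(C(=O)CC2CCCC2)c1O`: 1910 nM
compound 2 `CCCC(=O)c1ccc(OCCCCOc2ccc(F)c(C(=O)O)c2)c(C)c1O`: 438 nM
compound 3 `COc1ccc(C(=O)O)cc1OCCCCOc1ccc(C(=O)C(C)C)c(O)c1C`: 588 nM

Among the three numbers, compound 1 gives the highest value in this assay; compound 3 sits closest to it, and compound 2 furthest, both of these gaps lying beyond the usual scatter. Compounds 2 and 3 are within scatter of each other, so no order is drawn between them.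

The next member, compound 4 `Cc1c(OCCCCOc2cccc(C(=O)O)c2)ccc(C(=O)CC2CCCC2)c1O`, is not yet measured. Compared with compound 1, the change is 3-carboxyphenyl in place of (4-carboxyphenoxy)methyl on an oxygen on a saturated carbon. This shortens the link between the chain and the acid-bearing ring and places the carboxylic acid on a directly ether-linked ring, an arrangement that compounds 2 and 3 also carry, both of which gave lower numbers than compound 1.

On that basis compound 4 is expected to land closer to compounds 2 and 3 than to compound 1, with the estimated step of a 2.9-fold lower number from compound 1 to compound 4 (0.47 log units; beyond the scatter) going downward beyond the scatter. The estimate for compound 4 in this assay is 650 nM, within a range from 250 nM to 1700 nM.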

Compound 4, half-maximal effective concentration: 3400 nM
The estimate for compound 4 lay 5.2-fold (0.72 log units) below the measured number; measured number outside the range, above it.
By their numbers in this assay, from the lowest: compounds 2 and 3 (each within the scatter of the next); then compounds 1 and 4 (each within the scatter of the next).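

In this assay, 3-carboxyphenyl in place of (4-carboxyphenoxy)methyl on an oxygen on a saturated carbon gives a 1.8-fold higher number from compound 1 to compound 4 (0.25 log units; within the scatter). Within the data shown here, as the first one-place pair, this shows that the exchange does not separate the two compounds on the core of compound 1, although the leaving and entering groups differ in heavy atoms and hydrogen-bond acceptors. Compounds 2 and 3 differ from compound 4 in more than one place, and nothing on hand explains this result or ties their numbers to the directly linked acid-bearing ring.

Open, on these data alone, is how this position responds to a tetrazole or an amide in place of the carboxylic acid. Also open, as far as these compounds go, is whether the exchange reads the same on a core with a different group on the ketone carbonyl.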